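The source may report more compounds than this note shows. Statements on the series, on what has been measured and on what is new or still open speak of the compounds shown alone.

Measured so far in an ADME assay on liver (Mus musculus) for metabolic stability, read by LC-MS, using microsomes and NADPH; on this read-out higher numbers stand for a more stable compound and lower numbers for a less stable compound:
Compound 1 `CCCN(Cc1ccc(OCCN2C(=O)CCC2=O)c(C)c1)C(CC(=O)O)c1ccc(Cl)cc1` gives 75%.
Compound 2 `CCCCN(Cc1ccc(OCCN2C(=O)CCC2=O)c(C)c1)C(CC(=O)O)c1ccc(Cl)cc1` gives 88%.
Compound 3 `Cc1cc(CN(CC2CCCC2)[C@@H](CC(=O)O)c2ccc(Cl)cc2)ccc1OCCN1C(=O)CCC1=O` gives 69%.

Compound 1 and compound 2 differ in one place, (methyl in place of hydrogen on a saturated chain carbon, three bonds along the chain from an amine nitrogen), and this change brought a number 13 percentage points higher from compound 1 to compound 2 (beyond the scatter). Compound 3 is built on a different core, and how that core differs from the core of compound 1 is not broken down here; what the numbers show is that compound 2 stands higher than compound 3, while compound 3 and compound 1 lie close together.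

Compound 4 `CCc1cc(CN(CC2CCCC2)[C@@H](CC(=O)O)c2ccc(Cl)cc2)ccc1OCCN1C(=O)CCC1=O` is the not yet measured partner of compound 3. It carries methyl in place of hydrogen on a saturated chain carbon bound to an aromatic carbon. For the measured compounds named here, this is the same kind of change as the one from compound 1 to compound 2, but not the same: there the added methyl sat on a saturated chain carbon, three bonds along the chain from an amine nitrogen, here it sits on a saturated chain carbon bound to an aromatic carbon, and the core is another one. In this assay the step from compound 3 to compound 4 is expected to be a number 8 percentage points higher from compound 3 to compound 4 (within the scatter), resting on a number 13 percentage points higher from compound 1 to compound 2 (beyond the scatter) but tempered by the different place and core. Compound 4 is estimated at 77%, between 62% and 90%.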

Compound 4, percent of the compound remaining: 27%
The estimate for compound 4 lay 50 percentage points above the measured number; measured number below the stated range.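

In this assay the added methyl, which turns the methyl on the ring into an ethyl, brought a number 42 percentage points lower from compound 3 to compound 4 (beyond the scatter) and so ran the opposite way to the earlier step on the core of compound 1. Set side by side, the two steps show that this kind of change did not carry over from one core to the other: the same change on two cores in this assay, a number 13 percentage points higher (beyond the scatter) from compound 1 to compound 2 and a number 42 percentage points lower (beyond the scatter) from compound 3 to compound 4, 55 percentage points apart, beyond the scatter of two such steps

A gain from one added methyl therefore cannot be taken as a rule for this series, yet this single pair on each core does not show whether the place of the methyl or the core itself decides the outcome, as the two steps differ in both.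

The compounds shown leave open what the same methyl to ethyl change would do on the core of compound 1, which would help to separate place from core. They also leave open how a longer chain such as propyl, or a methoxy group, would fare in place of the ethyl on the core of compound 3.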